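The compounds below may be only part of what the source reports. "The series", "measured", "known", "first", "only" and "open" are said of these compounds alone.

Measured compounds:
compound 1 `CC[C@@H]1C(=O)N(C)c2cnc(Nc3ccc(S(=O)(=O)NC4CCCC4)cc3)nc2N1C1CCCC1` gives 389 nM;
compound 2 `CC[C@@H]1C(=O)N(C)c2cnc(-n3ccc4cc(C(=O)NC(C)C)ccc43)nc2N1C1CCCC1` gives 1660 nM;
compound 3 `CCC1C(=O)N(C)c2cnc(Nc3ccc(S(=O)(=O)NC)cc3)nc2N1c1ccn(C)n1` gives 11900 nM.

The three values come from a functional assay on Huh-7 cells (Homo sapiens) for antiproliferative activity, read by CCK-8 assay, with a stated time of 72 h; on this read-out higher numbers stand for weaker inhibition of growth and lower numbers for stronger inhibition of growth. Compound 1 stands at the lowest number of the three, and its distance to compound 2 and to compound 3 is in each case beyond the scatter, so among these compounds it is the strongest inhibitor of growth. Compound 2 lies closer to it, compound 3 furthest away.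

The step followed here leads from compound 1 to compound 4 `CC[C@@H]1C(=O)N(C)c2cnc(Nc3ccc(S(=O)(=O)NCC(C)C)cc3)nc2N1C1CCCC1`, which has not yet been tested. The structural change is isobutyl in place of cyclopentyl on a sulfonamide nitrogen. Both the leaving group and the entering group are plain alkyl groups of closely similar size with no donors or acceptors, and nothing else in the molecule moves. Among the measured compounds shown here, no measured pair of compounds in this set shows such a change on its own, so there is no step to lean on; the expectation rests on the closeness of the two groups alone. Compound 4 is expected to stay near compound 1, with a step of a 1.3-fold higher number from compound 1 to compound 4 (0.11 log units; within the scatter) that is not expected to reach beyond the scatter. The estimate for compound 4 in this assay is 500 nM, with a range from 200 nM to 1300 nM.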

Compound 4, concentration for 50% growth inhibition: 411 nM
For compound 4 the middle estimate is 1.2-fold (0.09 log units) above the measured one; the range from low to high includes it.
By their numbers in this assay, from the lowest: compounds 1 and 4 (each within the scatter of the next); then compound 2; then compound 3.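

In this assay, isobutyl in place of cyclopentyl on a sulfonamide nitrogen gives a 1.1-fold higher number from compound 1 to compound 4 (0.02 log units; within the scatter), so the two compounds cannot be told apart on this read-out. Among the compounds shown here, this is the first direct look at this place in the set, and it shows that a ring of carbon only on the sulfonamide nitrogen is not needed to keep the growth inhibition of compound 1: an open isobutyl group serves equally well here. No measurement is at hand that would explain this result.

On these data alone, what a chain ending in an amine or a carboxylic acid, or a phenyl ring, would do on the sulfonamide nitrogen remains open. Also open, as far as these compounds go, is whether a longer chain than isobutyl would still leave the value where it stands.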